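Exchanging the Amine on the Shared Amide Carbonyl

This account rests on a few compounds, and the source may have more. Where it says the series, first, only, none or still open, it means among the compounds named here.

Of the compounds shown here, two have been measured in a functional assay for antagonist activity at thyroid hormone receptor beta (Homo sapiens), read by fluorescence polarization, with a stated time of 3 h; a lower number here means a stronger inhibitor, a higher number a weaker inhibitor. Compound 1, `CN(Cc1cccc(F)c1)C(=O)c1cnc(-c2ccc(S(C)(=O)=O)c([N+](=O)[O-])c2)s1`, gives 8500 nM in this assay. Compound 2, `CC1(C)CC2CC(C)(CN2C(=O)c2sc(-c3ccc(S(C)(=O)=O)c([N+](=O)[O-])c3)nc2C(F)(F)F)C1`, gives 2100 nM. Compound 2 thus holds the lower of the two numbers, and the gap to compound 1 lies beyond the usual scatter. Going by the values given here, no single-point step between the two measured compounds is defined, since they differ in more than one place, so the two numbers can only be set side by side.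

Compound 3, `CN(Cc1cccc(F)c1)C(=O)c1sc(-c2ccc(S(C)(=O)=O)c([N+](=O)[O-])c2)nc1C(F)(F)F`, is not yet measured. Compared with compound 2, it carries a group of 10 heavy atoms (8 carbon, 1 nitrogen, 1 fluorine; one six-membered aromatic ring of carbon only) in place of a group of 11 heavy atoms (10 carbon, 1 nitrogen; one five-membered non-aromatic ring with 1 hetero atom, one six-membered non-aromatic ring of carbon only), on a carbonyl carbon. The new amine is the same one that compound 1 bears on its carbonyl, while the rest of compound 3 follows compound 2. Among the compounds with values here, with no measured step that isolates this exchange, the expectation rests on where the two numbers sit: compound 1, which carries this amine, gives 8500 nM, and compound 2 gives 2100 nM. On that basis compound 3 is expected to land between them, with a step of a 1.9-fold higher number from compound 2 to compound 3 (0.28 log units; within the scatter) from compound 2 toward a weaker number, which may or may not exceed the scatter. The estimate for compound 3 in this assay is 4000 nM, within a range from 1500 nM to 11000 nM.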

Compound 3, half-maximal inhibitory concentration: 2800 nM
Compound 3: middle estimate off by 1.4-fold (0.15 log units), on the high side, and the stated range covers the measured number.
By their numbers in this assay, from the lowest: compounds 2 and 3 (each within the scatter of the next); then compound 1.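

In this assay, placing the (3-fluorobenzyl)(methyl)amino group on the carbonyl carbon in place of the group carried by compound 2 gives a 1.3-fold higher number from compound 2 to compound 3 (0.12 log units; within the scatter), so with trifluoromethyl present on the shared core, this read-out does not separate the two amine groups. The other step holds the (3-fluorobenzyl)(methyl)amino group fixed and puts trifluoromethyl in place of hydrogen on an aromatic carbon, giving a 3.0-fold lower number from compound 1 to compound 3 (0.48 log units; beyond the scatter), a modest change and the only one of the two single changes that lies beyond the scatter. The earlier pair could not show either result, since those two compounds differ in more than one place, and nothing available bears on the reason for the size of either step.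

The compounds shown leave open whether a smaller or different group, such as methyl, chlorine or a nitrile, would serve on that aromatic carbon in place of trifluoromethyl. They also leave open whether the carbonyl position would respond in the same way to a different kind of amine, such as morpholine or piperazine, and what would follow from replacing the nitro group or the methylsulfonyl group.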